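Trimming the amide nitrogen chain down to methyl

The source may hold more compounds than are shown below. What is called first, only, known or untested is meant among the compounds shown, and "the series" means these compounds.

compound 1, `COc1c(C)cnc(CN2CC(=O)N(CC(C)C)c3c(Cl)nc(N)nc32)c1C`, gives 10 nM in a functional assay on SK-BR-3 cells (Homo sapiens) for inhibition; a lower number here means a stronger inhibitor, a higher number a weaker inhibitor.
compound 2, `COc1c(C)cnc(CN2CC(=O)N(C(C)C)c3c(Cl)nc(N)nc32)c1C`, gives 20 nM in this assay.
compound 3, `COc1c(C)cnc(CN2CC(=O)N(CCCC(C)C)c3c(Cl)nc(N)nc32)c1C`, gives 970 nM in this assay.

Among these three, compound 1 holds the lowest number. Compound 2 stands nearest to it, a 2.0-fold higher number from compound 1 to compound 2 (0.30 log units; within the scatter), and compound 3 stands furthest, a 97-fold higher number from compound 1 to compound 3 (1.99 log units; beyond the scatter). Compound 4, `COc1c(C)cnc(CN2CC(=O)N(C)c3c(Cl)nc(N)nc32)c1C`, differs from compound 1 in a single place: hydrogen in place of isopropyl on a saturated chain carbon bound to an amide-type nitrogen in a ring.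

Two kinds of measured step bear on this change. Removing one carbon from the chain on the amide-type nitrogen hardly moved the number, a 2.0-fold higher number from compound 1 to compound 2 (0.30 log units; within the scatter). Adding carbons, by contrast, cost much: a 97-fold higher number from compound 1 to compound 3 (1.99 log units; beyond the scatter) and a 49-fold higher number from compound 2 to compound 3 (1.69 log units; beyond the scatter). For the measured compounds named here, compound 4 goes further in the shortening direction than any measured compound, so the single within-scatter step is only a partial guide. A modest rise in the number is therefore expected, a 4.0-fold higher number from compound 1 to compound 4 (0.60 log units; beyond the scatter), with wide uncertainty. Compound 4 is estimated at 40 nM in this assay, within a range from 8 nM to 250 nM.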

Compound 4, half-maximal inhibitory concentration: 460 nM
Beside the measured number, compound 4's estimate is 12-fold (1.06 log units) below it; measured number outside the range, above it.
By their numbers in this assay, from the lowest: compounds 1 and 2 (each within the scatter of the next); then compound 4; then compound 3.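

In this assay, cutting isobutyl to methyl gives a 46-fold higher number from compound 1 to compound 4 (1.66 log units; beyond the scatter), and the same shortening from isopropyl gives a 23-fold higher number from compound 2 to compound 4 (1.36 log units; beyond the scatter), so shortening the chain on the amide-type nitrogen is not tolerated without limit. The number at this position therefore rises in both directions among these four compounds, with isobutyl and isopropyl holding the low numbers, although methyl still stands on the lower side of the longest chain, a 2.1-fold lower number from compound 3 to compound 4 (0.32 log units; beyond the scatter). Nothing available here accounts for the rise on either side.

Going by these compounds, it remains open how sharply the number changes with intermediate chains, such as ethyl or n-propyl on the short side and n-butyl on the long side. On these data alone, it is also open whether a cyclopropylmethyl group, or a chain ending in a hydroxyl or an amine, would hold the low number of compound 1.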